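The compounds below may be only part of what the source reports. "The series", "measured", "known", "first", "only" and "open" are said of these compounds alone.

Measured in a functional assay on DLD-1 cells (Homo sapiens) for antiproliferative activity, read by CellTiter-Glo, with a stated time of 72 h; on this read-out lower numbers stand for stronger inhibition and higher numbers for weaker inhibition: compound 1 `CC1CCN(C2CCN(S(=O)(=O)c3ccccc3Br)CC2)CC1` gives 3 nM; compound 3 `Cc1nc(Cl)sc1S(=O)(=O)N1CCC(N2CCC(C)CC2)CC1` gives 1.6 nM. Compound 2 `CC1CCN(C2CCN(S(=O)(=O)c3cccnc3F)CC2)CC1` gives only a limit, > 5000 nM (the limit of > 5000 nM in this assay, at which 1 of the 3 values shown sits).

Compound 3 has the lowest number shown, with compound 1 nearest, a 1.9-fold lower number from compound 1 to compound 3 (0.27 log units; within the scatter). Compound 4 `CC1CCN(C2CCN(S(=O)(=O)c3cccc(Br)c3)CC2)CC1` differs from compound 3 by 3-bromophenyl in place of 2-chloro-4-methyl-1,3-thiazol-5-yl on a sulfonyl sulfur. Among the compounds with values here, no measured step makes this exact change. The closest comparison is a 1.9-fold lower number from compound 1 to compound 3 (0.27 log units; within the scatter), which puts 2-bromophenyl and the thiazolyl close together, whereas an at least 3100-fold lower number from compound 2 to compound 3 (3.49 log units; beyond the scatter) shows that another ring on the sulfonyl sulfur can remove activity entirely. 3-Bromophenyl matches neither case. Weighing a 1.9-fold lower number from compound 1 to compound 3 (0.27 log units; within the scatter) against an at least 3100-fold lower number from compound 2 to compound 3 (3.49 log units; beyond the scatter), compound 4 is expected to give a moderately higher number, a 19-fold higher number from compound 3 to compound 4 (1.27 log units; beyond the scatter), with wide uncertainty. The estimate for compound 4 is 30 nM, between 3 nM and 600 nM.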

Compound 4, half-maximal inhibitory concentration: 3.2 nM
Compound 4: the middle estimate sits 9.4-fold (0.97 log units) above what was measured; the measured number falls inside the stated range.
By their numbers in this assay, from the lowest: compounds 3, 1 and 4 (each within the scatter of the next). At a limit, above all of these: compound 2.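

With the ring on the sulfonyl sulfur, 2-bromophenyl and 3-bromophenyl cannot be told apart, with a 1.1-fold higher number from compound 1 to compound 4 (0.03 log units; within the scatter), and 3-bromophenyl and 2-chloro-4-methyl-1,3-thiazol-5-yl cannot either, with a 2.0-fold higher number from compound 3 to compound 4 (0.30 log units; within the scatter). Among the compounds shown, only 2-fluoropyridin-3-yl stands apart, with an at least 1500-fold lower number from compound 2 to compound 4 (3.19 log units; beyond the scatter). Compound 2 gives a limit and not a number: the limit of > 5000 nM in this assay, at which 1 of the 4 values shown sits.

As far as these compounds go, it remains open whether a 2-fluorophenyl or a 2-bromopyridin-3-yl would read like compound 2 or like compound 4. From the compounds shown here alone, how an amine or a carboxylic acid on the phenyl ring would read also remains open.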